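Ethylamino in place of hydroxy on compound 3

The compounds below may be only part of what the source reports. "The series", "measured", "known", "first", "only" and "open" are said of these compounds alone.

In a functional assay on MCF7 cells (Homo sapiens) for antiproliferative activity, read by MTT assay, with a stated time of 48 h (a higher number here means a weaker inhibitor, a lower number a stronger inhibitor), compound 1 (`COc1ccc(C(=O)c2ccc3c(c2)C=CC(C)(C)O3)c(NC(=O)CBr)c1`) stands at 2880 nM and compound 2 (`COc1ccc(C(=O)c2ccc(OC)c3c2C=CC(C)(C)O3)c(NC(=O)CN)c1`) at 1250 nM on the same read-out. Compound 3 (`C=C(c1ccc(OC)cc1NC(=O)CO)c1ccc(OC)c2c1C=CC(C)(C)O2`) gives 590 nM as the lowest of the three numbers, beyond the scatter from both others. Compound 4 (`C=C(c1ccc(OC)cc1NC(=O)CNCC)c1ccc(OC)c2c1C=CC(C)(C)O2`) carries ethylamino in place of hydroxy on a saturated chain carbon bound to a carbonyl carbon. Within the data shown here, no measured pair isolates this change. Compound 2 also holds an amino group on that chain but differs elsewhere from compound 3, so the value of compound 2 at 1250 nM is only a loose guide. In this assay an estimated 1.2-fold higher number from compound 3 to compound 4 (0.07 log units; within the scatter) is expected, with no change beyond the scatter. Compound 4 is estimated at 700 nM (expected range 230 nM to 2100 nM).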

Compound 4, half-maximal inhibitory concentration: 2920 nM
Estimate against measurement, compound 4: 4.2-fold (0.62 log units) below, and the stated range ends below it.
By their numbers in this assay, from the lowest: compound 3; then compound 2; then compounds 1 and 4 (each within the scatter of the next).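

In this assay, among these compounds, the change to ethylamino from hydroxy on a saturated chain carbon bound to a carbonyl carbon gives a 4.9-fold higher number from compound 3 to compound 4 (0.69 log units; beyond the scatter) as the first reading of a single change at this place. This place is therefore not indifferent to the group it carries, and within this pair hydroxy holds the lower number. Nothing shown accounts for this step.

On these data alone, whether a dimethylamino group, a carboxylic acid or a longer chain here would read closer to compound 3 or to compound 4 remains open. Also open, as far as these compounds go, is whether this step holds on a different core.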